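A few compounds are considered here, and "the series" means these few. Any claim that something is new, unique, unknown or untested is made for them only; others in the source may bear on it.

Working notes on the series. For the measured compounds named here, compound 1 `O=C(NCc1ccc(CNS(=O)(=O)c2cccc(Cl)c2)cc1)c1ccc(CNc2ncccn2)cc1` is the reference point: in an assay on MDA-MB-231 cells for binding affinity to C-X-C chemokine receptor type 4 (Homo sapiens), read by microscopy, with stated times of 10 min and 30 min (on this read-out higher numbers stand for an effect only at larger amounts of compound and lower numbers for an effect already at smaller amounts), compound 1 gives 1 nM, the lowest of the two numbers so far. Going by the values given here, compound 2 `O=C(NCc1ccc(CNS(=O)(=O)c2ccccc2Cl)cc1)c1ccc(CNc2ncccn2)cc1` gives 1000 nM in this assay, and the single measured step, a 1000-fold higher number from compound 1 to compound 2 (3.00 log units; beyond the scatter), arises from 2-chlorophenyl in place of 3-chlorophenyl on the sulfonyl sulfur. Compound 3 `O=C(NCc1ccc(CNS(=O)(=O)c2ccc(F)c(F)c2)cc1)c1ccc(CNc2ncccn2)cc1` has not yet been measured in this assay. Its change from compound 1 is 3,4-difluorophenyl in place of 3-chlorophenyl on a sulfonyl sulfur. Among the compounds with values here, the one measured step concerns a shift of the chlorine to another position, not the exchange of chlorine for fluorine nor the arrival of a second fluorine, so it bears only loosely on this case; it shows that this part of the molecule is sensitive to change. The expected outcome is a small step in this assay, somewhat upward, well short of what compound 2 showed: for compound 3 the expected step is a 5.0-fold higher number from compound 1 to compound 3 (0.70 log units; beyond the scatter). Compound 3 is therefore estimated at 5 nM, with a range of 1 nM to 30 nM.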

Compound 3, effective concentration (reported as EC, without a stated level of effect): 100 nM
The estimate for compound 3 lay 20-fold (1.30 log units) below the measured number, outside the stated range (above it).
By their numbers in this assay, from the lowest: compound 1; then compound 3; then compound 2.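

In this assay 3,4-difluorophenyl in place of 3-chlorophenyl gives a 100-fold higher number from compound 1 to compound 3 (2.00 log units; beyond the scatter) and so shows that a large rise at this place on the sulfonyl sulfur does not depend on moving the chlorine to another position. Against 2-chlorophenyl the same group gives a 10-fold lower number from compound 2 to compound 3 (1.00 log units; beyond the scatter) so the three aryl groups spread into a graded order, and among the compounds shown only 3-chlorophenyl reaches the low end. Nothing available here accounts for this order.

The compounds shown leave open whether the low number is tied to chlorine itself, which 3-fluorophenyl or 3-bromophenyl on the sulfonyl sulfur would test. They also leave open whether an aromatic ring is needed there at all, as a plain butyl chain in its place would show.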